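The source may hold more compounds than are shown below. What is called first, only, known or untested is meant among the compounds shown, and "the series" means these compounds.

Measured so far

Compound 1, `NCCCCN(C[C@@H]1Cc2ncccc2CN1)[C@H]1CCCc2cccnc21`: in an ADME assay on microsomes from liver (Mus musculus) for metabolic stability, using NADPH, with a stated time of 10 min (a lower number here means that less of the compound is left, a higher number that more of the compound is left), compound 1 gives 75%
Compound 2, `NC/C=C/CN(C[C@H]1Cc2ncccc2CN1)[C@H]1CCCc2cccnc21`: in this assay compound 2 gives 37%

Notes

Of the compounds shown here, two carry a number so far. Compound 2 stands lowest of the two, and its nearest neighbour, compound 1, sits higher by a gap that lies beyond the usual scatter of the method. For the measured compounds named here, no step between the two measured compounds is tabulated as such, so only the two values themselves are set side by side here.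

The next compound in line is compound 3, `CN(CCCCN(C[C@H]1Cc2ncccc2CN1)[C@H]1CCCc2cccnc21)C1CCOCC1`. Relative to compound 2 the change is a group of 11 heavy atoms (9 carbon, 1 nitrogen, 1 oxygen; one six-membered non-aromatic ring with 1 hetero atom) in place of a group of 4 heavy atoms (3 carbon, 1 nitrogen; no ring), on a saturated chain carbon bound to an amine nitrogen. With that change, compound 3 is to be run in this assay.

Going by the values given here, there is no measured step of this kind to lean on. The expectation is that the value will move upward from compound 2, and that the step of a number 18 percentage points higher from compound 2 to compound 3 (beyond the scatter) will be of a size beyond the scatter, though this is an estimate only. For compound 3 the expected value is 55%, with a range from 30% to 80%, again an estimate to be checked against the measurement.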

Compound 3, percent of the compound remaining: 51%
Compound 3: middle estimate off by 4 percentage points, on the high side; the measured number falls inside the stated range.
By their numbers in this assay, from the lowest: compound 2; then compound 3; then compound 1.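

Replacing 3-aminoprop-1-en-1-yl with a group of 11 heavy atoms carrying a six-membered non-aromatic ring, on a saturated chain carbon bound to an amine nitrogen, gives a number 14 percentage points higher from compound 2 to compound 3 (beyond the scatter) in this assay. For the compounds shown here, this is the first readable step at this position, and it shows that the position tolerates a much larger group, one with a ring and no hydrogen-bond donor, without a loss in the percent of compound remaining. The step changes several things at once (the size of the group, the ring, the double bond outside aromatic rings and the donor count), and nothing measured here bears on why the number rises or separates these contributions.

Still open, from the compounds shown here alone, is how a simple dimethylamine or a piperidine ring would read in this assay at this position, which would show whether the gain needs the ring or its oxygen. Going by these compounds, compound 1 differs from compound 2 and compound 3 in more than one place, so whether the step carries over to the core of compound 1 also remains open.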